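Adding a third methoxy group to the hydroxybenzimidazole core

A few compounds are considered here, and "the series" means these few. Any claim that something is new, unique, unknown or untested is made for them only; others in the source may bear on it.

Compound 1 `c1ccc(-c2ccc(-c3ccc(-c4nc5ccccc5[nH]4)cc3)cc2)cc1` and compound 2 `COc1ccc(-c2ccc(-c3ccc(-c4nc5ccccc5[nH]4)cc3)cc2)cc1` share one core, while compound 3 `COc1ccc(-c2ccc(-c3ccc(-c4nc5c(O)cccc5[nH]4)cc3)cc2)cc1OC` and the unmeasured compound 4 `COc1cc(-c2ccc(-c3ccc(-c4nc5c(O)cccc5[nH]4)cc3)cc2)cc(OC)c1OC` share another; the difference between the two cores is not broken down here. In a functional assay on KB cells (Homo sapiens) for inhibition, read by sulforhodamine B assay (on this read-out lower numbers stand for stronger inhibition of growth and higher numbers for weaker inhibition of growth), compound 1 gives 39700 nM and compound 2 gives 47200 nM. Their difference, (methoxy in place of hydrogen on an aromatic carbon), amounts to a 1.2-fold higher number from compound 1 to compound 2 (0.08 log units; within the scatter). In this assay compound 3 gives 2710 nM, the lowest of the three values. Compound 4 carries the same kind of change, (methoxy in place of hydrogen on an aromatic carbon), but here the entering group sits ortho to a methoxy group, meta to a large group and meta to a methoxy group, whereas in compound 2 it sits para to a large group. Because a 1.2-fold higher number from compound 1 to compound 2 (0.08 log units; within the scatter) stayed within the scatter, the expected step for compound 4 is a 1.1-fold higher number from compound 3 to compound 4 (0.04 log units; within the scatter). Compound 4 is therefore estimated at 3000 nM, likely between 1200 nM and 7500 nM.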

Compound 4, concentration for 50% growth inhibition: 2110 nM
Estimate against measurement, compound 4: 1.4-fold (0.15 log units) above; the measured number falls inside the stated range.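

In this assay, methoxy in place of hydrogen on an aromatic carbon gives a 1.3-fold lower number from compound 3 to compound 4 (0.11 log units; within the scatter). The two cores show no measurable difference in how they respond to this replacement: the same change on two cores in this assay, a 1.2-fold higher number (0.08 log units; within the scatter) from compound 1 to compound 2 and a 1.3-fold lower number (0.11 log units; within the scatter) from compound 3 to compound 4, 1.5-fold (0.18 log units) apart, within the scatter of two such steps. This shows that the step stays within the scatter on both cores, at the two places it occupies here, but it does not show that the same would hold on another core or at another place.

From the compounds shown here alone, whether an amine, a carboxylic acid or a longer chain on the same carbon would give a step beyond the scatter remains open. Also open is which of the differences between the two cores accounts for the gap between their values.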